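Swapping Thiophen-2-yl for Pyridin-4-yl on Compound 3

The source may hold more compounds than are shown below. What is called first, only, known or untested is meant among the compounds shown, and "the series" means these compounds.

In a functional assay on HCT-15 cells (Homo sapiens) for cytotoxicity, read by ELISA, with a stated time of 2 days (a higher number here means a weaker inhibitor, a lower number a stronger inhibitor), compound 3 (`Oc1cccc(-c2cc(-c3ccccc3)nc(-c3cccs3)c2)c1`) gives 14100 nM. Compound 2 (`Oc1ccc(-c2cc(-c3ccccc3)cc(-c3cccnc3)n2)cc1`) lies within the scatter of that number at 15100 nM. Compound 1 (`Oc1ccc(-c2cc(-c3ccccc3)cc(-c3ccco3)n2)cc1`) reads 3500 nM, a smaller number and beyond the scatter of both.

The next compound, compound 4 (`Oc1cccc(-c2cc(-c3ccccc3)nc(-c3ccncc3)c2)c1`), carries pyridin-4-yl in place of thiophen-2-yl on an aromatic carbon, next to the ring nitrogen: pyridin-4-yl in place of thiophen-2-yl on an aromatic carbon. The 3-hydroxyphenyl group and the phenyl group stay as they are.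

Among the measured compounds shown here, only one measured step bears on this change: a 4.3-fold higher number from compound 1 to compound 2 (0.63 log units; beyond the scatter), with pyridin-3-yl in place of furan-2-yl. It is an imperfect guide, since neither ring in that step is the one exchanged here, and the core of compound 1 differs from that of compound 3. The values also urge caution: compound 2, with pyridin-3-yl, and compound 3, with thiophen-2-yl, read alike, although their cores differ. A rise in this assay is therefore expected, but a smaller one than the measured step, and it may not clear the scatter. The expected change is a 1.7-fold higher number from compound 3 to compound 4 (0.23 log units; within the scatter). The estimate for compound 4 is 24000 nM, with an expected range from 9000 nM to 60000 nM.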

Compound 4, half-maximal inhibitory concentration: 18700 nM
Compound 4: the middle estimate sits 1.3-fold (0.11 log units) above what was measured; the range from low to high includes it.
By their numbers in this assay, from the lowest: compound 1; then compounds 3, 2 and 4 (each within the scatter of the next).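

In this assay, the exchange of thiophen-2-yl for pyridin-4-yl on the aromatic carbon next to the ring nitrogen reads as a 1.3-fold higher number from compound 3 to compound 4 (0.12 log units; within the scatter), so on this core the five-membered and six-membered aromatic rings, each with one hetero atom, are not told apart. Among the compounds shown here, the only earlier step, a 4.3-fold higher number from compound 1 to compound 2 (0.63 log units; beyond the scatter), lay beyond the scatter, but it involved two other rings on a different core, and this pair now gives a first reading at this position with the 3-hydroxyphenyl and phenyl groups held fixed. No accompanying measurement offers an explanation for this result.

The compounds shown leave open whether furan-2-yl, which compound 1 carries at 3500 nM, would give a lower number on the core shared by compound 3 and compound 4. They also leave open whether a group that is not an aromatic ring, such as a primary amine, a carboxylic acid or a longer alkyl chain, would read differently from thiophen-2-yl and pyridin-4-yl at this position.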